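Removing the tert-butyl in a glutamate receptor modulator series

The compounds below may be only part of what the source reports. "The series", "measured", "known", "first", "only" and "open" are said of these compounds alone.

Compound 1 `Cc1c(OCCCCOc2ccc(F)c(C(=O)O)c2)ccc(C(=O)CC(C)(C)C)c1O` gives 102% in an assay on HEK293 cells for positive allosteric modulation of metabotropic glutamate receptor 3 (Rattus norvegicus), read by thallium flux, with a stated time of 2.5 min; a higher number here means a larger maximal response, a lower number a smaller maximal response. Compound 2 `Cc1c(OCCCCOc2ccc(C(=O)CC(C)(C)C)c(O)c2C)cccc1C(=O)O` gives 109% in this assay; the two cores differ as 3-carboxy-2-methylphenyl in place of 3-carboxy-4-fluorophenyl on an oxygen on a saturated carbon, and the step is a number 7 percentage points higher from compound 1 to compound 2 (within the scatter). Compound 3 `CC(=O)c1ccc(OCCCCOc2ccc(F)c(C(=O)O)c2)c(C)c1O` gives 16.8% in this assay; it arises from compound 1 through (hydrogen in place of tert-butyl on a saturated chain carbon bound to a carbonyl carbon), and the step is a number 85.2 percentage points lower from compound 1 to compound 3 (beyond the scatter). Compound 4 `CC(=O)c1ccc(OCCCCOc2cccc(C(=O)O)c2C)c(C)c1O` has not yet been measured; it arises from compound 2 through (hydrogen in place of tert-butyl on a saturated chain carbon bound to a carbonyl carbon), the same change at a place described in the same words. Going by the values given here, compound 4 is therefore expected to show a step of a number 84 percentage points lower from compound 2 to compound 4 (beyond the scatter) because a number 85.2 percentage points lower from compound 1 to compound 3 (beyond the scatter) is the one prior instance of this change on a core that differs only as described. The estimate for compound 4 in this assay is 25%, with the likely range running from 10% to 50%.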

Compound 4, largest response reached (reported as percent of maximum), in percent of the reference or control that the assay uses: 17.1%
Beside the measured number, compound 4's estimate is 7.9 percentage points above it, within the range that was stated.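

In this assay the change from tert-butyl to hydrogen on compound 2 gives a number 91.9 percentage points lower from compound 2 to compound 4 (beyond the scatter) and leaves compound 4 with a low maximal response. Carried from one core to the other, the change removes a similar amount of the response: the same change on two cores in this assay, a number 85.2 percentage points lower (beyond the scatter) from compound 1 to compound 3 and a number 91.9 percentage points lower (beyond the scatter) from compound 2 to compound 4, 6.7 percentage points apart, within the scatter of two such steps

This shows that the loss holds on these two cores, which differ as 3-carboxy-2-methylphenyl and 3-carboxy-4-fluorophenyl, but it does not show that it would hold on any other core or explain why the response falls. The compounds shown leave open how the response changes between the two ends of this series, neopentylcarbonyl and acetyl. An ethyl, an isopropyl or a cyclohexyl in place of the tert-butyl could show whether part of the response remains with a smaller or different group.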